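Compound 2 and the sulfur side chain

A few compounds are considered here, and "the series" means these few. Any claim that something is new, unique, unknown or untested is made for them only; others in the source may bear on it.

Compound 1 (`CCSc1nnc(-c2cc(OC)c(OC)c(OC)c2)n1-c1ccc(OC)cc1`) gives > 60000 nM in a functional assay on HCT-116 cells (Homo sapiens) for inhibition, read by MTT assay, with a stated time of 48 h (on this read-out lower numbers stand for stronger inhibition and higher numbers for weaker inhibition), as a limit of the assay. Compound 2 (`CCSc1nnc(-c2cc(OC)c(OC)c(OC)c2)n1-c1ccc(N(C)C)cc1`) gives > 60000 nM as a limit too. Compound 2 thus stands at the limit of > 60000 nM in this assay, at which 2 of the 2 values shown sit, with no number. Among the compounds with values here, the sole measured step is a step that the two limits leave unreadable from compound 1 to compound 2 and it lies at another place. Compound 3 (`COc1cc(-c2nnc(SCc3ccc(F)cc3)n2-c2ccc(N(C)C)cc2)cc(OC)c1OC`) carries 4-fluorophenyl in place of methyl on a saturated chain carbon bound to a sulfur. Within the data shown here, no measured step bears on this place. Only a move toward stronger inhibition can be read in this assay because compound 2 gives > 60000 nM as a limit. The expected change is an at least 6.0-fold lower number from compound 2 to compound 3 (0.77 log units; beyond the scatter) and its size is uncertain. For compound 3 the estimated value is 10000 nM with an expected range from 800 nM to 60000 nM in this series.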

Compound 3, half-maximal inhibitory concentration: > 60000 nM
Compound 3: only a limit was reported; the forecaster's own chance of this, stated with the estimate: 35%; middle value at least 6.0-fold (0.77 log units) away from the limit.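

No step can be read from compound 2 to compound 3, since both values are limits of the assay: the limit of > 60000 nM in this assay, at which 3 of the 3 values shown sit.
Which change to the shared series, if any, brings a value inside the readable range of this assay stays open.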